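Cyclohexyl to 4-Fluorophenyl: Compound 2 to Compound 3

A few compounds are considered here, and "the series" means these few. Any claim that something is new, unique, unknown or untested is made for them only; others in the source may bear on it.

Compound 1 `O=C(/C(=C/C1CCCCC1)CCl)c1ccccc1`: 29000 nM in a functional assay on T47D cells (Homo sapiens) for inhibition, read by sulforhodamine B assay, with a stated time of 48 h; on this read-out higher numbers stand for weaker inhibition of growth and lower numbers for stronger inhibition of growth
Compound 2 `CC(=O)OC/C(=C\C1CCCCC1)C(=O)c1ccccc1`: 22000 nM

Among the measured compounds shown here, the two measured numbers lie within the scatter of each other, as the single step shows: a 1.3-fold lower number from compound 1 to compound 2 (0.12 log units; within the scatter). Compound 3 `CC(=O)OC/C(=C\c1ccc(F)cc1)C(=O)c1ccccc1` differs from compound 2 by 4-fluorophenyl in place of cyclohexyl on a double-bonded chain carbon bound to a double-bonded chain carbon. For the measured compounds named here, the one measured step concerns a different place on the chain and so does not bear on this change; no measured step does. Compound 3 is therefore expected to give a number near that of compound 2, a step of a 1.5-fold lower number from compound 2 to compound 3 (0.17 log units; within the scatter), with the estimate for compound 3 being 15000 nM within a wide range from 3000 nM to 60000 nM.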

Compound 3, concentration for 50% growth inhibition: 14000 nM
The estimate for compound 3 lay 1.1-fold (0.03 log units) above the measured number, within the range that was stated.
By their numbers in this assay, from the lowest: compounds 3, 2 and 1 (each within the scatter of the next, the first and the last beyond it).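

Among the compounds shown here, the earlier step concerned only the saturated chain carbon; this one is the first look at the ring on the double-bonded chain carbon. In this assay, 4-fluorophenyl and cyclohexyl at this place give numbers within the scatter of each other (a 1.6-fold lower number from compound 2 to compound 3 (0.20 log units; within the scatter)), so an aromatic ring carrying fluorine and a non-aromatic ring of carbon only serve alike here. Nothing available explains this similarity. On these data alone, whether plain phenyl would match these two remains open, as does whether an amine or a carboxylic acid at this place would hold the number in the same range.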